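The source may hold more compounds than are shown below. What is called first, only, known or untested is meant among the compounds shown, and "the series" means these compounds.

In a functional assay on HCT-116 cells (Homo sapiens) for cytotoxicity, read by MTT assay, with a stated time of 48 h (on this read-out higher numbers stand for weaker inhibition of growth and lower numbers for stronger inhibition of growth), compound 1 (`CCn1c(C(F)(F)F)nc2cc(Cl)c(Cl)cc21`) gives 95300 nM and compound 2 (`FC(F)(F)c1nc2cc(Cl)c(Cl)cc2n1CC1CC1`) gives 61300 nM. Compound 3 (`Clc1cc2ncn(C3CCCC3)c2cc1Cl`) gives 37000 nM, which lies within the scatter of the number for compound 2 and is lower than the number for compound 1 by more than the scatter. Compound 4 (`FC(F)(F)c1nc2cc(Cl)c(Cl)cc2n1C1CCCC1`) differs from compound 3 by trifluoromethyl in place of hydrogen on an aromatic carbon, with trifluoromethyl in place of hydrogen on an aromatic carbon. For the measured compounds named here, no measured step covers this change directly. Compounds 1 and 2 both carry trifluoromethyl, but each also differs from compound 3 in the group on the ring nitrogen, so they offer only a loose guide. Going by the values given here, the one measured step, a 1.6-fold lower number from compound 1 to compound 2 (0.19 log units; within the scatter), changes that group while trifluoromethyl stays in place. With compound 2 at 61300 nM as the nearest guide, no shift beyond the scatter is expected in this assay, with only a slight lean toward a higher number. The expected change is a 1.4-fold higher number from compound 3 to compound 4 (0.13 log units; within the scatter). Compound 4 is estimated at 50000 nM, with an expected range of 22000 nM to 110000 nM.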

Compound 4, concentration for 50% growth inhibition: 22000 nM
Estimate against measurement, compound 4: 2.3-fold (0.36 log units) above; measured number inside the range.
By their numbers in this assay, from the lowest: compounds 4, 3, 2 and 1 (each within the scatter of the next, the first and the last beyond it).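

In this assay, for the compounds shown here, trifluoromethyl in place of hydrogen on the aromatic carbon between two ring nitrogen atoms, with the cyclopentyl group held constant, gives a 1.7-fold lower number from compound 3 to compound 4 (0.23 log units; within the scatter), so this is the first direct reading of the change, and it does not separate the two groups. With trifluoromethyl held constant, cyclopentyl on the aromatic nitrogen instead gives a 2.8-fold lower number from compound 2 to compound 4 (0.45 log units; beyond the scatter) and a 4.3-fold lower number from compound 1 to compound 4 (0.64 log units; beyond the scatter). Both of these steps at the nitrogen pass the scatter, although a 1.6-fold lower number from compound 1 to compound 2 (0.19 log units; within the scatter), also at the nitrogen, does not.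

The compounds shown leave open whether a nitrile or a carboxylic acid on this carbon would read differently, and whether hydrogen and trifluoromethyl would also read alike with ethyl or cyclopropylmethyl on the nitrogen. No evidence given here accounts for any of these steps.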